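A few compounds are considered here, and "the series" means these few. Any claim that something is new, unique, unknown or untested is made for them only; others in the source may bear on it.

Of the compounds shown here, three that share one core have been measured in a functional assay on Molt4/C8 cells (Homo sapiens) for cytotoxicity; a higher number here means a weaker inhibitor, a lower number a stronger inhibitor. Compound 3 `O=C(/C=C/C(=O)N1C/C(=C\c2ccccc2)C(=O)/C(=C/c2ccccc2)C1)Nc1ccccc1` gives 520 nM, the lowest of the three numbers; compound 1 `Cc1ccc(NC(=O)/C=C/C(=O)N2C/C(=C\c3ccccc3)C(=O)/C(=C/c3ccccc3)C2)cc1` gives 660 nM, and compound 2 `Cc1ccc(NC(=O)/C=C/C(=O)N2C/C(=C\c3ccccc3)C(=O)/C(=C/c3ccccc3)C2)cc1C` gives 7900 nM. Compound 3 and compound 1 lie within the scatter of each other, as the step of a 1.3-fold lower number from compound 1 to compound 3 (0.10 log units; within the scatter) shows, while compound 2 sits well apart: a 15-fold lower number from compound 2 to compound 3 (1.18 log units; beyond the scatter).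

Compound 4 `O=C(/C=C/C(=O)N1C/C(=C\c2ccccc2)C(=O)/C(=C/c2ccccc2)C1)Nc1ccc(Cl)cc1` differs from compound 3 by chloro in place of hydrogen on an aromatic carbon.

Which measured steps bear on this? All three concern substituents on the same anilide ring. A single methyl there made no difference beyond the scatter: a 1.3-fold lower number from compound 1 to compound 3 (0.10 log units; within the scatter). A second methyl on that ring, however, cost a great deal: a 12-fold higher number from compound 1 to compound 2 (1.08 log units; beyond the scatter), and removing both at once recovered it: a 15-fold lower number from compound 2 to compound 3 (1.18 log units; beyond the scatter). Compound 4 carries one substituent only, a chloro, at the place where a single methyl was tolerated. He therefore expects no step beyond the scatter in this assay, with a slight risk toward a weaker compound if the ring is sensitive to any addition.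

Compound 4 is expected to give 600 nM, within a range from 250 nM to 2000 nM, a step of a 1.2-fold higher number from compound 3 to compound 4 (0.06 log units; within the scatter).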

Compound 4, half-maximal inhibitory concentration: 1800 nM
Estimate against measurement, compound 4: 3.0-fold (0.48 log units) below, and the stated range covers the measured number.
By their numbers in this assay, from the lowest: compounds 3 and 1 (each within the scatter of the next); then compound 4; then compound 2.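

In this assay, among these compounds, the chloro group shows that this aromatic carbon, para to a large group, does not treat every single substituent alike: the step of a 3.5-fold higher number from compound 3 to compound 4 (0.54 log units; beyond the scatter) lies beyond the scatter, whereas the earlier compounds had suggested that one small group on this ring changed little. The direct exchange of the two groups, a 2.7-fold higher number from compound 1 to compound 4 (0.44 log units; beyond the scatter), is also beyond the scatter, so chloro and methyl are not interchangeable in this series. The loss is nevertheless not as large as that seen with the 3,4-dimethylphenyl group, as the step of a 4.4-fold lower number from compound 2 to compound 4 (0.64 log units; beyond the scatter) shows, which places the 4-chlorophenyl compound apart from both the low pair, compound 3 and compound 1, and the high compound 2.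

The compounds shown leave open whether fluoro, bromo, methoxy or an amine at this same carbon would stay close to compound 3 or shift the number as chloro does, and whether chloro elsewhere on the ring would behave the same way. Nothing available here explains why chloro and methyl differ at this carbon.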